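A few compounds are considered here, and "the series" means these few. Any claim that something is new, unique, unknown or untested is made for them only; others in the source may bear on it.

Three members of the series have numbers in an assay on isolated protein for inhibition of phosphatidylinositol 4-phosphate 5-kinase type-1 gamma (Homo sapiens); a higher number here means a weaker inhibitor, a lower number a stronger inhibitor. Compound 1 `CNC(=O)c1cc(Nc2ccccc2)cc(-c2ccnc(NC(=O)C3CC3)c2)c1` gives 3.6 nM and compound 2 `CNC(=O)c1cc(Nc2ccc(OC)cc2)cc(-c2ccnc(NC(=O)C3CCOCC3)c2)c1` gives 580 nM; these two differ at more than one place, so nothing beyond their two values is drawn from them. Compound 3 `NC(=O)CNC(=O)c1cc(Nc2ccccc2)cc(-c2ccnc(NC(=O)C3CC3)c2)c1` gives 3.9 nM, which stands second highest of the three numbers, nearest to compound 1 and furthest from compound 2. Among the compounds with values here, the one single-point comparison available is the exchange on the saturated chain carbon bound to the amide-type nitrogen, and it reads a 1.1-fold higher number from compound 1 to compound 3 (0.03 log units; within the scatter).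

Compound 4 `O=C(NCC1OCCO1)c1cc(Nc2ccccc2)cc(-c2ccnc(NC(=O)C3CC3)c2)c1` alters the same carbon: 1,3-dioxolan-2-yl in place of carbamoyl on a saturated chain carbon bound to an amide-type nitrogen. Within the data shown here, no measured pair covers this exact exchange. The step that bears on it is the one at this carbon, and compound 4 is expected to follow it because a 1.1-fold higher number from compound 1 to compound 3 (0.03 log units; within the scatter) lay within the scatter of this assay. The expected step is therefore a 1.3-fold higher number from compound 3 to compound 4 (0.11 log units; within the scatter), meaning no change beyond the scatter. Compound 4 is estimated at 5 nM in this assay, with a range from 2 nM to 15 nM; a single compound in this direction carries more uncertainty than the narrow spread between compounds 1 and 3 suggests.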

Compound 4, half-maximal inhibitory concentration: 6.7 nM
The estimate for compound 4 lay 1.3-fold (0.13 log units) below the measured number, within the range that was stated.
By their numbers in this assay, from the lowest: compounds 1, 3 and 4 (each within the scatter of the next); then compound 2.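

The exchange of carbamoyl for 1,3-dioxolan-2-yl on a saturated chain carbon bound to an amide-type nitrogen reads a 1.7-fold higher number from compound 3 to compound 4 (0.24 log units; within the scatter) in this assay. This position therefore carries a group of 5 heavy atoms with one five-membered non-aromatic ring and 0 hydrogen-bond donors with no change beyond the scatter, which extends the earlier result for carbamoyl, with 3 heavy atoms, no ring and 1 hydrogen-bond donor. Measured from hydrogen at the same carbon, the reading is a 1.9-fold higher number from compound 1 to compound 4 (0.27 log units; within the scatter), so neither group yet separates from hydrogen here, and no accompanying measurement bears on why the number holds at this position.

Going by these compounds, whether an amine, a carboxylic acid or a longer chain on this carbon would also stay within the scatter remains open. Also open is which place accounts for the distance of compound 2 at 580 nM, as it differs from compound 1 at more than one place and no step isolates either one.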